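This account rests on a few compounds, and the source may have more. Where it says the series, first, only, none or still open, it means among the compounds named here.

Of the compounds shown here, three sharing one core have been tested in a functional assay on the whole organism (Tail, strain ICR) with Mus musculus as the target, in the tail flick test, with a stated time of 30 min, at a dose of 25 umol/kg by the oral route; a higher number here means a stronger effect of the compound at the dose given, a lower number a weaker effect. Compound 3 `CC(C)C[C@H](NC(=O)CN(c1nc(Cl)nc2[nH]cnc12)C1CC1)C(=O)O` gives 23.4%. Compound 1 `NC(=O)C[C@H](NC(=O)CN(c1nc(Cl)nc2[nH]cnc12)C1CC1)C(=O)O` differs from compound 3 only where (carbamoyl in place of isopropyl on a saturated chain carbon, two bonds along the chain from an amide-type nitrogen and a carbonyl carbon), and compound 1 gives 29.7%, a step of a number 6.3 percentage points higher from compound 3 to compound 1 (within the scatter). Compound 2 `CC(C)C[C@H](NC(=O)CN(c1nc(Cl)nc2[nH]cnc12)C1CC1)C(=O)OCc1ccccc1` differs from compound 3 where (benzyl in place of hydrogen on an oxygen next to a carbonyl group), which is also how the core of compound 2 differs from the core of compound 3; compound 2 gives 33.9%, a step of a number 10.5 percentage points lower from compound 2 to compound 3 (beyond the scatter). Compound 4 `NC(=O)C[C@H](NC(=O)CN(c1nc(Cl)nc2[nH]cnc12)C1CC1)C(=O)OCc1ccccc1` has not yet been measured. It differs from compound 2 where (carbamoyl in place of isopropyl on a saturated chain carbon, two bonds along the chain from an amide-type nitrogen and a carbonyl carbon). For the measured compounds named here, this is the same change as the one from compound 3 to compound 1, at a place described in the same words, so the two steps can be set side by side. The step from compound 2 to compound 4 is expected to be about a number 5.1 percentage points higher from compound 2 to compound 4 (within the scatter), resting on the step of a number 6.3 percentage points higher from compound 3 to compound 1 (within the scatter) seen on the other core. Compound 4 is therefore estimated at 39%, with a likely range from 27% to 51%.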

Compound 4, a percentage reported as activity, at one dose (the size of the read-out at that dose, not a potency): 24.4%
Compound 4: the middle estimate sits 14.6 percentage points above what was measured; the measured number lies below the stated range.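

In this assay, putting carbamoyl in place of isopropyl does not carry over from one core to the other, as the new step of a number 9.5 percentage points lower from compound 2 to compound 4 (within the scatter) does not match the earlier one: the same change on two cores in this assay, a number 6.3 percentage points higher (within the scatter) from compound 3 to compound 1 and a number 9.5 percentage points lower (within the scatter) from compound 2 to compound 4, 15.8 percentage points apart, beyond the scatter of two such steps Putting benzyl in place of hydrogen on the oxygen gives a step of a number 5.3 percentage points lower from compound 1 to compound 4 (within the scatter), and this also fails to match its counterpart on the other core: the same change on two cores in this assay, a number 10.5 percentage points lower (beyond the scatter) from compound 2 to compound 3 and a number 5.3 percentage points higher (within the scatter) from compound 4 to compound 1, 15.8 percentage points apart, beyond the scatter of two such steps Both comparisons rest on the same four compounds, so they show that the two changes do not simply add up here, but not why, nor whether this would hold for other groups.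

The compounds shown leave open how a methyl ester in place of the benzyl ester would behave on either core. They also leave open whether a carboxylic acid or an amine in place of carbamoyl would give a step that carries over between the two cores.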